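Cinnamic acid series: heteroaryl exchange on the olefin

The source may hold more compounds than are shown below. What is called first, only, known or untested is meant among the compounds shown, and "the series" means these compounds.

Measured so far in a functional assay on MCF7 cells (Homo sapiens) for cytotoxicity, read by CellTiter-Glo, with a stated time of 5 days; on this read-out higher numbers stand for weaker inhibition and lower numbers for stronger inhibition:
compound 1 `O=C(O)/C=C/c1ccc(/C(=C(\c2ccccc2)C(F)F)c2ccc3[nH]ncc3c2)cc1`: 14 nM
compound 2 `O=C(O)/C=C/c1ccc(/C(=C(\c2ccccc2)C2CC2)c2ccc3[nH]ncc3c2)cc1`: 13 nM
compound 3 `CC/C(=C(/c1ccc(/C=C/C(=O)O)cc1)c1ccc2[nH]ncc2n1)c1ccccc1`: 33 nM

In this assay compound 3 stands highest of the three, with compound 1 and compound 2 both lower by more than the scatter. Compound 4 `CC/C(=C(/c1ccc(/C=C/C(=O)O)cc1)c1cc2cn[nH]c2cc1Cl)c1ccccc1` differs from compound 3 by a group of 10 heavy atoms (7 carbon, 2 nitrogen, 1 chlorine; one five-membered aromatic ring with 2 hetero atoms, one six-membered aromatic ring of carbon only) in place of a group of 9 heavy atoms (6 carbon, 3 nitrogen; one five-membered aromatic ring with 2 hetero atoms, one six-membered aromatic ring with 1 hetero atom), on a double-bonded chain carbon bound to an aromatic carbon and a double-bonded chain carbon. Among the measured compounds shown here, the only measured step, a 1.1-fold lower number from compound 1 to compound 2 (0.03 log units; within the scatter), concerns a different substituent and does not bear on this exchange. For the measured compounds named here, compound 1 and compound 2 carry a related group at this place yet differ from compound 3 elsewhere too, so their values show only that such compounds can sit lower than compound 3. The number for compound 4 is therefore expected modestly lower, a 1.8-fold lower number from compound 3 to compound 4 (0.26 log units; within the scatter), with wide uncertainty. The estimate for compound 4 is 18 nM, range 6 nM to 55 nM.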

Compound 4, half-maximal inhibitory concentration: 137 nM
The estimate for compound 4 lay 7.6-fold (0.88 log units) below the measured number, and the stated range ends below it.
By their numbers in this assay, from the lowest: compounds 2 and 1 (each within the scatter of the next); then compound 3; then compound 4.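

In this assay, the group on a double-bonded chain carbon bound to an aromatic carbon and a double-bonded chain carbon matters: 6-chloro-1H-indazol-5-yl in place of the group with a six-membered aromatic ring with 1 hetero atom gives a 4.2-fold higher number from compound 3 to compound 4 (0.62 log units; beyond the scatter), the only step shown that lies beyond the scatter. The exchange is not tolerated as a neutral swap on this core. No measured property bears on this step.

Going by these compounds, the exchange alters the six-membered ring and adds chlorine together, so the share of each remains open. The unchlorinated 1H-indazol-5-yl group, or fluorine or a methyl group in place of the chlorine, on the core of compound 3 would separate them.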